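Swapping Phenyl for Pyridinyl on a Phosphate Ester

A few compounds are considered here, and "the series" means these few. Any claim that something is new, unique, unknown or untested is made for them only; others in the source may bear on it.

Of the compounds shown here, three have been measured in a physicochemical assay for metabolic stability, read by HPLC, tested at 2 mM; on this read-out higher numbers stand for a longer-lived compound and lower numbers for a shorter-lived compound. Compound 1 `O=C(O[C@H]1C[C@H](n2cc(F)c(=O)[nH]c2=O)O[C@@H]1COP(=O)(O)Oc1ccccc1)c1ccccc1` gives 6.6 h in this assay. Compound 2 `O=C(O[C@H]1C[C@H](n2cc(F)c(=O)[nH]c2=O)O[C@@H]1COP(=O)(O)Oc1cccnc1)c1ccccc1` gives 6.7 h. Compound 3 `O=c1[nH]c(=O)n([C@H]2C[C@H](O)[C@@H](COP(=O)(O)Oc3ccccc3)O2)cc1F` gives 28 h, the highest of the three numbers. The step of a 4.2-fold higher number from compound 1 to compound 3 (0.63 log units; beyond the scatter) came with hydrogen in place of benzoyl on an oxygen on a saturated carbon, and it lies beyond the scatter.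

Compound 4 `O=c1[nH]c(=O)n([C@H]2C[C@H](O)[C@@H](COP(=O)(O)Oc3cccnc3)O2)cc1F` has not yet been measured. It differs from compound 3 by pyridin-3-yl in place of phenyl on an oxygen. Going by the values given here, only one measured step bears on this exchange: a 1.0-fold higher number from compound 1 to compound 2 (0.01 log units; within the scatter), which made the same change on the same kind of oxygen and left the half-life within the scatter. There is nothing in the measured compounds to suggest that the same exchange would behave differently when made on compound 3 rather than on compound 1.

Compound 4 is therefore expected to give about 28 h in this assay, with a range from 17 h to 45 h. The step this estimate means, no change at the digits printed from compound 3 to compound 4 (within the scatter), is expected to stay within the scatter of repeated measurements, in no clear direction.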

Compound 4, half-life: 16.7 h
For compound 4 the middle estimate is 1.7-fold (0.22 log units) above the measured one; the measured number lies below the stated range.
By their numbers in this assay, from the lowest: compounds 1 and 2 (each within the scatter of the next); then compounds 4 and 3 (each within the scatter of the next).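

In this assay, the exchange of phenyl for pyridin-3-yl on the oxygen bound to phosphorus has now been read with a free hydroxyl as well as with a benzoyl ester elsewhere on the molecule: a 1.7-fold lower number from compound 3 to compound 4 (0.22 log units; within the scatter) lies within the scatter, as does a 1.0-fold higher number from compound 1 to compound 2 (0.01 log units; within the scatter) in the benzoylated pair. So across these two pairs, the choice between the two aromatic groups gives no step beyond the scatter, whichever group sits on the other oxygen. The new pair also tests the benzoyl exchange with pyridin-3-yl in place: a 2.5-fold higher number from compound 2 to compound 4 (0.40 log units; beyond the scatter) lies beyond the scatter and runs in the same direction as a 4.2-fold higher number from compound 1 to compound 3 (0.63 log units; beyond the scatter), so the pattern now holds with both aromatic groups, and nothing shown explains either step.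

On these data alone, both exchanges have been read only with these few groups, so it remains open whether an acetyl ester on the same oxygen would give a number nearer that of compound 2 or that of compound 4. As far as these compounds go, it is also open whether an amine or a carboxylic acid on the aromatic ring would leave the half-life within the scatter, as the ring nitrogen of pyridin-3-yl did.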